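Swapping Hydroxyphenyl for Chlorophenyl on the Sulfonamide

The source may report more compounds than this note shows. Statements on the series, on what has been measured and on what is new or still open speak of the compounds shown alone.

Three measured compounds share one core and differ only in the aryl group on the sulfonyl sulfur. In an assay on cells for inhibition of HSP60/HSP10 (Homo sapiens), with a stated time of 60 min (a lower number here means a stronger inhibitor, a higher number a weaker inhibitor), compound 1, `Cc1cccc(S(=O)(=O)Nc2ccc(-c3nc4ccccc4o3)cc2)c1`, gives only a limit, > 100000 nM. Compound 2, `O=S(=O)(Nc1ccc(-c2nc3ccccc3o2)cc1)c1cccc(C(F)(F)F)c1`, gives 57000 nM. Compound 3, `O=S(=O)(Nc1ccc(-c2nc3ccccc3o2)cc1)c1cccc(O)c1`, gives 62000 nM. On the numbers shown, compound 3 sits together with compound 2, and the single step between two numbers is a 1.1-fold higher number from compound 2 to compound 3 (0.04 log units; within the scatter). The other steps, an at least 1.7-fold lower number from compound 1 to compound 2 (0.24 log units; that floor lies within the scatter) and an at least 1.6-fold lower number from compound 1 to compound 3 (0.20 log units; that floor lies within the scatter), each start from the limit and cannot be sized further.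

Compound 4, `O=S(=O)(Nc1ccc(-c2nc3ccccc3o2)cc1)c1ccc(Cl)cc1`, is not yet measured. Its change from compound 3 is 4-chlorophenyl in place of 3-hydroxyphenyl on a sulfonyl sulfur. Among the compounds with values here, no measured step places a 4-chlorophenyl group on the sulfonyl sulfur, and every measured step between the three aryl groups has stayed within the scatter. The expectation in this assay is a step no larger than that scatter, in no particular direction. Compound 4 is thus expected to give about 60000 nM, between 20000 nM and 150000 nM. That corresponds to an expected step of a 1.0-fold lower number from compound 3 to compound 4 (0.01 log units; within the scatter).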

Compound 4, half-maximal inhibitory concentration: 61000 nM
Compound 4: the middle estimate sits 1.0-fold (0.01 log units) below what was measured, within the range that was stated.
By their numbers in this assay, from the lowest: compounds 2, 4 and 3 (each within the scatter of the next). At a limit, above all of these: compound 1.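

Moving from the 3-hydroxyphenyl group to the 4-chlorophenyl group on the sulfonyl sulfur takes away the hydrogen-bond donor and acceptor counted for the hydroxy group, yet the result is a 1.0-fold lower number from compound 3 to compound 4 (0.01 log units; within the scatter). Unlike the earlier steps, this one changes both the substituent and its printed ring position, so compounds 2, 3 and 4 show that three differently substituted aryl groups can give numbers within the scatter of one another. Compound 1 remains a limit, so an at least 1.6-fold lower number from compound 1 to compound 4 (0.21 log units; that floor lies within the scatter) cannot be sized further: the limit of > 100000 nM in this assay, at which 1 of the 4 values shown sits.

From the compounds shown here alone, whether an amine or a carboxylic acid on the aryl ring, or a longer chain on the sulfonyl sulfur, would give a step beyond the scatter remains open. All the compounds shown keep the shared core, so the effect of changing it also remains open.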